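Methoxy on the aromatic ring of compound 1

This account rests on a few compounds, and the source may have more. Where it says the series, first, only, none or still open, it means among the compounds named here.

Compound 1, `CC(C)(C)OC(=O)/C=C1/C(=O)Nc2ccccc21`, is the reference of this small set. In a toxicity assay on L02 cells (Homo sapiens) for cytotoxicity, read by CCK-8 assay, with a stated time of 72 h (a lower number here means a stronger inhibitor, a higher number a weaker inhibitor), compound 1 gives 2450 nM, the lowest of the three numbers recorded. Two neighbours differ from it in one place each. Compound 2, `CN1C(=O)/C(=C/C(=O)OC(C)(C)C)c2ccccc21`, carries a methyl in place of hydrogen on the amide-type ring nitrogen and gives 4320 nM; this is a 1.8-fold higher number from compound 1 to compound 2 (0.25 log units; within the scatter). Compound 3, `CCCCc1ccc2c(c1)/C(=C\C(=O)OC(C)(C)C)C(=O)N2`, carries a butyl in place of hydrogen on an aromatic carbon and gives 4400 nM; this is a 1.8-fold higher number from compound 1 to compound 3 (0.25 log units; within the scatter). Both changes thus leave the number within the scatter of compound 1, if anything slightly higher.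

Compound 4, `COc1ccc2c(c1)NC(=O)/C2=C/C(=O)OC(C)(C)C`, is not yet measured. It differs from compound 1 by methoxy in place of hydrogen on an aromatic carbon. For the measured compounds named here, the step that bears most directly on it is the one from compound 1 to compound 3, another substitution on an aromatic carbon of the same ring, which was small. The methylation step was of the same size. A change on the aromatic ring is therefore expected to shift the number little, at most modestly upward, so the expected step is a 1.4-fold higher number from compound 1 to compound 4 (0.14 log units; within the scatter). Compound 4 is estimated at 3400 nM, with a range from 1500 nM to 8000 nM.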

Compound 4, half-maximal inhibitory concentration: 4340 nM
Compound 4: middle estimate off by 1.3-fold (0.11 log units), on the low side, and the stated range covers the measured number.
By their numbers in this assay, from the lowest: compounds 1, 2, 4 and 3 (each within the scatter of the next).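

Placed on this aromatic carbon, meta to a fused ring and para to a fused ring, methoxy gives a step that stays within the scatter in this assay (a 1.8-fold higher number from compound 1 to compound 4 (0.25 log units; within the scatter)). Compound 3 had shown this only for butyl, a carbon chain, whereas methoxy adds an oxygen and a hydrogen-bond acceptor, so the result extends the observation to a substituent of a different kind on the aromatic ring of the shared core. Across the three single changes from compound 1, no step yet lies beyond the scatter, and no compound shown goes against this; no measurement here accounts for the result, so it stands as an observation only.

Still open, as far as these compounds go, is whether an amine or a carboxylic acid on this same aromatic carbon would also stay within the scatter of compound 1, or whether either would produce a step beyond it. Also open is whether a longer alkoxy chain in place of methoxy would behave in the same way, since the compounds shown hold only this one oxygen-linked group.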